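This account rests on a few compounds, and the source may have more. Where it says the series, first, only, none or still open, it means among the compounds named here.

Measured compounds:
Compound 1 `CCCc1cc(N2CCCCC2)c2cc(NC(=O)/C=C/c3ccc(C(F)(F)F)cc3)ccc2n1`: > 4000 nM.
Compound 2 `CCCc1ccc(/C=C/C(=O)Nc2ccc3nc(CCC)cc(N)c3c2)cc1`: 4 nM.
Compound 3 `CCCc1cc(N)c2cc(NC(=O)C3CCC(c4ccc(Cl)cc4)CC3)ccc2n1`: 4.4 nM.

Compound 1 gives in an assay on isolated protein for displacement of a labelled ligand from melanin-concentrating hormone receptor 1 (Homo sapiens) (on this read-out higher numbers stand for weaker inhibition and lower numbers for stronger inhibition), only a limit of the assay, > 4000 nM, not a number (the limit of > 4000 nM in this assay, at which 1 of the 3 values shown sits). Among the two numbers that remain, compound 2 sits at 4 nM, and compound 3 at 4.4 nM lies within the scatter of it, so the two cannot be told apart. Compound 4 `CCCc1cc(N)c2cc(NC(=O)/C=C/c3ccc(C(C)C)cc3)ccc2n1` has not been measured yet. It differs from compound 2 in one place: isopropyl in place of propyl on an aromatic carbon. Among the compounds with values here, as no measured pair carries the same change, the step is expected to stay within the scatter, in either direction: a 1.5-fold higher number from compound 2 to compound 4 (0.18 log units; within the scatter). Compound 4 is therefore estimated at 6 nM, between 2 nM and 20 nM.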

Compound 4, half-maximal inhibitory concentration: 2.9 nM
The estimate for compound 4 lay 2.1-fold (0.32 log units) above the measured number; measured number inside the range.
By their numbers in this assay, from the lowest: compounds 4, 2 and 3 (each within the scatter of the next). At a limit, above all of these: compound 1.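

In this assay, the change of 4-propylphenyl to 4-isopropylphenyl gives a 1.4-fold lower number from compound 2 to compound 4 (0.14 log units; within the scatter), the first step read at this position, para to a large group. A straight chain and a branched chain of the same size on this aromatic carbon therefore cannot be told apart here. Nothing measured here bears on why the two groups read alike.

The compounds shown leave open whether a longer chain, such as hexyl, would hold the number at this position. They also leave open what an amine or a carboxylic acid would do there.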